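Shifting the pyridine attachment point from compound 2 to compound 4

This account rests on a few compounds, and the source may have more. Where it says the series, first, only, none or still open, it means among the compounds named here.

Compound 2 `O=C(c1ccccc1)N1CCn2nc(-c3cccnc3)cc2C1` carries a pyridin-3-yl group on the shared core. In a functional assay on HEK293 cells for negative allosteric modulation of metabotropic glutamate receptor 5 (Homo sapiens), read by calcium flux, with a stated time of 20 min (a higher number here means a weaker inhibitor, a lower number a stronger inhibitor), compound 2 gives > 10000 nM, which is a limit of the assay and not a number. It sits at the limit of > 10000 nM in this assay, at which 1 of the 3 values shown sits. Compound 1 `O=C(c1ccccc1)N1CCn2nc(-c3ccncc3)cc2C1` differs only in the ring attachment, and in this assay compound 1 gives 1290 nM. For the measured compounds named here, the one measured step that bears on the change is an at least 7.7-fold higher number from compound 1 to compound 2 (0.88 log units; beyond the scatter). Going by the values given here, compound 3 `O=C(c1cc(Cl)cc(Cl)c1)N1CCn2nc(-c3ccccn3)cc2C1` carries a pyridin-2-yl group together with a dichlorobenzoyl amide, and in this assay compound 3 gives 270 nM; no single-change step links it to compound 2 or to compound 4, so its value only shows that a pyridin-2-yl bearer can reach this range.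

Compound 4 `Cc1ccc(-c2cc3n(n2)CCN(C(=O)c2ccccc2)C3)nc1` differs from compound 2 by 5-methylpyridin-2-yl in place of pyridin-3-yl on an aromatic carbon. Since moving the attachment point from pyridin-4-yl to pyridin-3-yl cost potency in compound 2, the step back to a pyridin-2-yl bearer is expected to recover it, and compound 4 is estimated to show an at least 25-fold lower number from compound 2 to compound 4 (1.39 log units; beyond the scatter). Compound 4 is estimated at 400 nM in this assay, with a range from 80 nM to 2500 nM.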

Compound 4, half-maximal inhibitory concentration: 244 nM
Compound 4: the middle estimate sits 1.6-fold (0.21 log units) above what was measured; measured number inside the range.
By their numbers in this assay, from the lowest: compounds 4 and 3 (each within the scatter of the next); then compound 1. At a limit, above all of these: compound 2.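

This position can therefore gain potency as well as lose it: with the benzoyl amide unchanged, 5-methylpyridin-2-yl gives an at least 40-fold lower number from compound 2 to compound 4 (1.61 log units; beyond the scatter) in this assay, and against the pyridin-4-yl bearer it gives a 5.3-fold lower number from compound 1 to compound 4 (0.72 log units; beyond the scatter). The value of compound 2 remains a limit of the assay, not a number: the limit of > 10000 nM in this assay, at which 1 of the 4 values shown sits. The earlier step showed only a loss on going from pyridin-4-yl to pyridin-3-yl, whereas compound 4 now stands beyond the scatter on the better side of compound 1, so the three pyridine groups on this aromatic carbon are separated in this series.

Both new steps change the attachment of the pyridine and add the methyl at once, so the compounds shown do not tell how much of the gain belongs to each, and a plain pyridin-2-yl group on the benzoyl amide would be needed to split them. Also open, as far as these compounds go, is whether the methyl itself can be replaced on the pyridine, for example by an amine, a methoxy group or a longer chain, and how such groups would read in this assay.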